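Piperidine in place of triazole on the shared core

The compounds below may be only part of what the source reports. "The series", "measured", "known", "first", "only" and "open" are said of these compounds alone.

Of the compounds shown here, three built on one core have been measured so far: compound 1 `O=C1c2c[n+]([O-])c3ccccc3c2C(=O)c2c1c1ccccc1n2Cc1cn([C@H]2C[C@H](O)[C@@H](CO)O2)nn1`, compound 2 `O=C1c2c[n+]([O-])c3ccccc3c2C(=O)c2c1c1ccccc1n2Cc1cn(CC(O)CO)nn1` and compound 3 `O=C1c2c[n+]([O-])c3ccccc3c2C(=O)c2c1c1ccccc1n2CCCCN1CCCCC1`. In a toxicity assay on L02 cells (Homo sapiens) for cytotoxicity, read by MTT assay, with a stated time of 72 h (on this read-out higher numbers stand for weaker inhibition and lower numbers for stronger inhibition), compound 1 gives 280 nM, compound 2 gives 1070 nM and compound 3 gives 610 nM. Compound 2 stands at the highest number of the three, though its gap to compound 3 is within the scatter, while the step of a 3.8-fold higher number from compound 1 to compound 2 (0.58 log units; beyond the scatter) is beyond it. The unmeasured compound 4 `O=C1c2c[n+]([O-])c3ccccc3c2C(=O)c2c1c1ccccc1n2CCN1CCCCC1` differs from compound 2 by (piperidin-1-yl)methyl in place of 1-(2,3-dihydroxypropyl)-1H-1,2,3-triazol-4-yl on a saturated chain carbon bound to an aromatic nitrogen. For the measured compounds named here, one measured step bears on this change, a 1.8-fold lower number from compound 2 to compound 3 (0.24 log units; within the scatter), which swapped the same group for 3-(piperidin-1-yl)propyl and lay within the scatter. Compound 4 is therefore expected to fall close to compound 3, an estimated step of a 1.6-fold lower number from compound 2 to compound 4 (0.22 log units; within the scatter). The estimate for compound 4 is 650 nM, within 280 nM to 1500 nM.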

Compound 4, half-maximal inhibitory concentration: 1050 nM
Compound 4: the middle estimate sits 1.6-fold (0.21 log units) below what was measured; the measured number falls inside the stated range.
By their numbers in this assay, from the lowest: compound 1; then compounds 3, 4 and 2 (each within the scatter of the next).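

The step of a 1.0-fold lower number from compound 2 to compound 4 (0.01 log units; within the scatter) in this assay shows that, on this saturated chain carbon, (piperidin-1-yl)methyl and 1-(2,3-dihydroxypropyl)-1H-1,2,3-triazol-4-yl cannot be told apart, despite their different hydrogen-bond donor counts. The step of a 1.7-fold higher number from compound 3 to compound 4 (0.24 log units; within the scatter) is also within the scatter, so 2-(piperidin-1-yl)ethyl and piperidin-1-yl at this place cannot be told apart either. Nothing measured here accounts for these results. From the compounds shown here alone, whether a morpholine, a primary amine or a carboxylic acid in place of the piperidine would move the number beyond the scatter remains open.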